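This account rests on a few compounds, and the source may have more. Where it says the series, first, only, none or still open, it means among the compounds named here.

Compound 1 `COc1ccc(-c2cc(/C=C/C(=O)c3ccc(N)cc3)[nH]n2)cc1`: 24400 nM
Compound 2 `COc1cc(-c2cc(/C=C/C(=O)c3ccc(N)cc3)[nH]n2)cc(OC)c1OC`: > 100000 nM
Compound 3 `COc1cc(-c2cc(/C=C/C(=O)c3ccc(Cl)c(Cl)c3)[nH]n2)cc(OC)c1OC`: > 100000 nM

All three share the same core and were tested in a functional assay on Hs-578T cells (Homo sapiens) for inhibition, read by sulforhodamine B assay, with a stated time of 48 h; a lower number here means a stronger inhibitor of growth, a higher number a weaker inhibitor of growth. Compound 1 gives a measurable value, 24400 nM. For compound 2 the assay gives only a limit, > 100000 nM, so its true value is not known, and it sits at the limit of > 100000 nM in this assay, at which 2 of the 3 values shown sit. For compound 3 the result is likewise a limit, > 100000 nM. The step that the two limits leave unreadable from compound 2 to compound 3 therefore cannot be sized, as both ends are limits.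

Compound 4 `COc1ccc(-c2cc(/C=C/C(=O)c3ccc(N)cc3)[nH]n2)cc1OC` has not yet been measured. It differs from compound 2 by hydrogen in place of methoxy on an aromatic carbon. Within the data shown here, no measured step covers this exact change, and the only guide is that compound 4 stands between compound 1 and compound 2 in the number of methoxy groups on that ring. Compound 4 is therefore expected to give about 60000 nM in this assay, with a range from 15000 nM to 200000 nM. This would mean an estimated step of an at least 1.6-fold lower number from compound 2 to compound 4 (0.22 log units; that floor lies within the scatter), although with compound 2 known only as a limit, the size of that step is itself uncertain.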

Compound 4, concentration for total growth inhibition: > 100000 nM
Compound 4 gave a limit, no number; the forecaster's own chance of this, stated with the estimate: 40%; at least 1.6-fold (0.22 log units) between middle value and limit.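

In this assay, a single methoxy in place of hydrogen on an aromatic carbon, ortho to a methoxy group, is enough to weaken growth inhibition: the change gives an at least 4.0-fold higher number from compound 1 to compound 4 (0.61 log units; beyond the scatter). Taking one methoxy away from compound 2 does not restore a measurable value, as compound 4 also ends at a limit rather than a number. The steps with a limit at both ends, including the one for this change, cannot be read, and this assay groups these compounds only at its edge: the limit of > 100000 nM in this assay, at which 3 of the 4 values shown sit.

From the compounds shown here alone, how far compound 2 and compound 4 lie past that limit remains open, and so does whether the third methoxy matters at all. Going by these compounds, it is also open whether a hydroxyl or a fluorine at this place would keep a readable value, as hydrogen does in compound 1.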